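The compounds below may be only part of what the source reports. "The series", "measured", "known", "first", "only" and "open" are said of these compounds alone.

- compound 1 `CCN(CC)CN1C(=O)/C(=N/NC(=S)Nc2ccc(OC)cc2)c2ccccc21` gives 2400 nM in a functional assay on L1210 cells (Mus musculus) for inhibition, read by cell counting, with a stated time of 48 h; a higher number here means a weaker inhibitor, a lower number a stronger inhibitor
- compound 2 `CCN(CC)CN1C(=O)/C(=N/NC(=S)Nc2ccc(OC)cc2)c2cc(Cl)ccc21` gives 11000 nM in this assay

Compound 1 has the lower of these two numbers, making it the stronger inhibitor of the pair. Compound 3 `CCN(CC)CN1C(=O)/C(=N/NC(N)=S)c2ccccc21` changes compound 1 as follows: hydrogen in place of 4-methoxyphenyl on an amide-type nitrogen in words, hydrogen in place of 4-methoxyphenyl on an amide-type nitrogen. Among the measured compounds shown here, no measured step covers this change. For the measured compounds named here, the only guide to size is a 4.6-fold higher number from compound 1 to compound 2 (0.66 log units; beyond the scatter) for a different change, so it is a rough one. A step of similar size toward a higher number in this assay is expected, though the direction is a judgement. The estimated step is a 3.3-fold higher number from compound 1 to compound 3 (0.52 log units; beyond the scatter) with wide uncertainty. The expected value for compound 3 is 8000 nM within an estimated range from 2000 nM to 30000 nM in this assay.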

Compound 3, half-maximal inhibitory concentration: 121000 nM
Beside the measured number, compound 3's estimate is 15-fold (1.18 log units) below it, outside the stated range (above it).
By their numbers in this assay, from the lowest: compound 1; then compound 2; then compound 3.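

The step of a 50-fold higher number from compound 1 to compound 3 (1.70 log units; beyond the scatter) in this assay shows that the group on this amide-type nitrogen matters a great deal: with hydrogen in place of 4-methoxyphenyl, the compound is a much weaker inhibitor. The earlier compounds shown here showed only a chloro change on an aromatic carbon, which gave the smaller step of a 4.6-fold higher number from compound 1 to compound 2 (0.66 log units; beyond the scatter). Still open, from the compounds shown here alone, is whether a plain phenyl, a methyl or a butyl chain on this nitrogen would keep the strength of compound 1. No measurement shown here explains the size of this loss.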